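Two Bromines in Place of a Methoxy Group

The compounds below may be only part of what the source reports. "The series", "measured", "known", "first", "only" and "open" are said of these compounds alone.

In a functional assay on the whole organism (6C3HED cells, Mus musculus) for inhibition, at a dose of 300 mg/kg by the oral route (on this read-out lower numbers stand for less inhibition and higher numbers for more inhibition at the one dose given (going by the name of the read-out)), three compounds have been measured so far:
compound 1 `CCc1ccc(S(=O)(=O)NC(=O)Nc2ccc(Cl)cc2)[nH]1` gives 56%
compound 2 `CCc1ccsc1S(=O)(=O)NC(=O)Nc1ccc(Cl)cc1` gives 25%
compound 3 `COc1csc(S(=O)(=O)NC(=O)Nc2ccc(Cl)cc2)c1` gives 69%

Compound 3 stands highest of the three: compound 1 is nearest, with a number 13 percentage points higher from compound 1 to compound 3 (beyond the scatter), and compound 2 is furthest, with a number 44 percentage points higher from compound 2 to compound 3 (beyond the scatter). Between the other two the step was a number 31 percentage points lower from compound 1 to compound 2 (beyond the scatter). All three share the same core; only the ring on the sulfonyl sulfur changes, and that ring alone moves the read-out by large amounts.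

Compound 4 `O=C(Nc1ccc(Cl)cc1)NS(=O)(=O)c1cc(Br)c(Br)s1` has not yet been measured. Its change from compound 3 is 4,5-dibromothiophen-2-yl in place of 4-methoxythiophen-2-yl on a sulfonyl sulfur. Among the measured compounds shown here, no measured step swaps a substituent for bromines, so nothing points directly at the outcome. For the measured compounds named here, the steps that bear on it are a number 44 percentage points higher from compound 2 to compound 3 (beyond the scatter) and a number 13 percentage points higher from compound 1 to compound 3 (beyond the scatter), which show that altering the ring on the sulfonyl sulfur can shift the read-out by a large amount in either direction. Because compound 3 already gives 69%, a drop seems more likely than a further rise. Compound 4 is therefore expected at 50%, with a range from 25% to 75%. This means a step of a number 19 percentage points lower from compound 3 to compound 4 (beyond the scatter) is expected.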

Compound 4, a percentage reported as inhibition, in the whole organism at one dose (the size of the read-out at that dose, not a potency): 52%
For compound 4 the middle estimate is 2 percentage points below the measured one; the range from low to high includes it.
By their numbers in this assay, from the lowest: compound 2; then compounds 4 and 1 (each within the scatter of the next); then compound 3.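

Measured in this assay, two bromines on the thiophene ring give a number 17 percentage points lower from compound 3 to compound 4 (beyond the scatter) when they replace the methoxy compound's group, and a number 27 percentage points higher from compound 2 to compound 4 (beyond the scatter) when they replace the ethyl-bearing thiophene, so the new ring lands between those two earlier rings. Against the 5-ethyl-1H-pyrrol-2-yl ring the change is a number 4 percentage points lower from compound 1 to compound 4 (within the scatter) and the two rings cannot be told apart on this read-out. The thiophene ring alone does not fix the number at this position, since compounds 2, 3 and 4 all carry it and their substituents still separate them.

Nothing measured here explains these differences. On these data alone, whether a single bromine would serve as well as two, or how an amine or a carboxylic acid on this ring would fare, remains open.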